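The compounds below may be only part of what the source reports. "The series", "measured", "known", "first", "only" and "open" are said of these compounds alone.

Compound 1, `OC[C@H]1O[C@@H](n2cnc3c(NCc4ccccc4F)ncnc32)[C@H](O)[C@@H]1O`, and compound 2, `OC[C@H]1O[C@@H](n2cnc3c(NCc4ccc(F)cc4F)ncnc32)[C@H](O)[C@@H]1O`, share a core and differ only in the group on a saturated chain carbon bound to a nitrogen on an aromatic ring. In a functional assay on CCRF-CEM cells (Homo sapiens) for antiproliferative activity, with a stated time of 72 h (on this read-out lower numbers stand for stronger inhibition and higher numbers for weaker inhibition), compound 1 gives 4600 nM, and compound 2 gives 7100 nM. Going by the values given here, the only step measured so far, a 1.5-fold higher number from compound 1 to compound 2 (0.19 log units; within the scatter), is small; compound 2 stands at the highest of the two numbers, and its nearest neighbour is compound 1, within the scatter.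

Compound 3, `COc1cccc(CNc2ncnc3c2ncn3[C@@H]2O[C@H](CO)[C@@H](O)[C@H]2O)c1O`, is built from compound 2 by a larger exchange: 2-hydroxy-3-methoxyphenyl in place of 2,4-difluorophenyl on a saturated chain carbon bound to a nitrogen on an aromatic ring. Among the compounds with values here, no measured step bears directly on this change, since the single step seen, from compound 1 to compound 2, swaps only fluoro for hydrogen on an aromatic carbon and stays within the scatter. Without a comparable step, no direction can be read from the data, and the default expectation is a number close to that of compound 2, with wide uncertainty.

Compound 3 is therefore expected to give 7000 nM in this assay, within a range from 2000 nM to 25000 nM. The expected step of a 1.0-fold lower number from compound 2 to compound 3 (0.01 log units; within the scatter) is estimated to stay within the scatter.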

Compound 3, half-maximal inhibitory concentration: 300 nM
Compound 3: middle estimate off by 23-fold (1.37 log units), on the high side; the measured number lies below the stated range.
By their numbers in this assay, from the lowest: compound 3; then compounds 1 and 2 (each within the scatter of the next).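

Until now this position had shown only the small step of a 1.5-fold higher number from compound 1 to compound 2 (0.19 log units; within the scatter), which says little about how much the group there matters. In this assay, putting 2-hydroxy-3-methoxyphenyl in place of 2,4-difluorophenyl gives a 24-fold lower number from compound 2 to compound 3 (1.37 log units; beyond the scatter), and putting it in place of 2-fluorophenyl gives a 15-fold lower number from compound 1 to compound 3 (1.19 log units; beyond the scatter), so two separate comparisons agree that this exchange brings much stronger inhibition and that the group on this saturated chain carbon bound to a nitrogen on an aromatic ring can matter greatly to the read-out. No measurement shown here explains why this exchange has so large an effect.

On these data alone, the hydroxy and the methoxy arrive together in compound 3, so it remains open whether 2-hydroxyphenyl alone or 3-methoxyphenyl alone would give a similar number, or whether the pair is needed. Also open, as far as these compounds go, is how far the trend reaches, for example whether an amino group or a carboxylic acid on the same phenyl ring would keep, extend or lose the stronger inhibition seen with compound 3.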